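Swapping a Cyclohexylmethyl Amine for Dimethylamino

The compounds below may be only part of what the source reports. "The series", "measured", "known", "first", "only" and "open" are said of these compounds alone.

Two compounds sharing one core were tested in a functional assay on CHO cells for antagonist activity at adenosine receptor A2b (Homo sapiens); on this read-out lower numbers stand for stronger inhibition and higher numbers for weaker inhibition. Compound 1 `CNC(=O)c1cnc(NC(=O)NC2CCCCC2)n2nc(-c3ccco3)nc12` reaches only the limit of the assay, > 30000 nM, rather than a number. Compound 2 `CCOC(=O)c1cnc(NCC2CCCCC2)n2nc(-c3ccco3)nc12` likewise reaches only a limit, > 10000 nM. Compound 2 thus stands at the limit of > 10000 nM in this assay, at which 1 of the 2 values shown sits, and no closer reading of it is known. Compound 3 `CCOC(=O)c1cnc(N(C)C)n2nc(-c3ccco3)nc12` differs from compound 2 by one change: dimethylamino in place of (cyclohexylmethyl)amino on an aromatic carbon. Without any measured step to lean on, the expected shift in this assay is a step that the limit leaves unreadable from compound 2 to compound 3, meaning none beyond the scatter. Compound 3 is therefore estimated at 20000 nM, within 3000 nM to 100000 nM.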

Compound 3, inhibition constant: > 10000 nM
Compound 3: only a limit was reported; the forecaster's own chance of this, stated with the estimate: 80%; the middle value lies beyond the limit too.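

Within the data shown here, compound 2 and compound 3 each give only a limit, so no step between them can be read. The compounds shown leave open how strongly either actually inhibits, and whether swapping (cyclohexylmethyl)amino for dimethylamino changes anything.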